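A few compounds are considered here, and "the series" means these few. Any claim that something is new, unique, unknown or untested is made for them only; others in the source may bear on it.

Compound 2 `COc1ccc(CNC(=O)/C(C#N)=C/c2ccc[nH]2)cc1` has no number in a functional assay on DU-145 cells (Homo sapiens) for inhibition, read by MTT assay, with a stated time of 72 h; a lower number here means a stronger inhibitor of growth, a higher number a weaker inhibitor of growth; compound 2 gives only the limit > 50000 nM. The other measured compounds also sit at limits. Compound 1 `N#C/C(=C\c1c(F)c(F)c(F)c(F)c1F)C(=O)c1ccc[nH]1` gives a limit of > 100000 nM in this assay. Compound 3 `N#C/C(=C\c1ccc[nH]1)C(=O)NCc1ccc(Cl)c(Cl)c1` gives a limit of > 50000 nM in this assay. So compound 2 stands among limits alone: the limit of > 50000 nM in this assay, at which 2 of the 3 values shown sit, and (the limit of > 100000 nM in this assay, at which 1 of the 3 values shown sits). Compound 4 `COc1ccc(CNC(=O)/C(C#N)=C/c2ccc(Cl)cc2)cc1` is not yet measured in this assay. It differs from compound 2 by 4-chlorophenyl in place of 1H-pyrrol-2-yl on a double-bonded chain carbon bound to a double-bonded chain carbon. Within the data shown here, no step between measured compounds exists, so the size and direction of this change in this assay are unknown; a move beyond the scatter either way cannot be excluded. Compound 4 is expected near 40000 nM, within 10000 nM to 100000 nM. The estimated step is an at least 1.2-fold lower number from compound 2 to compound 4 (0.09 log units; that floor lies within the scatter).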

Compound 4, concentration for 50% growth inhibition: 7000 nM
Estimate against measurement, compound 4: 5.7-fold (0.76 log units) above; measured number below the stated range.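

The change to 4-chlorophenyl in place of 1H-pyrrol-2-yl on a double-bonded chain carbon bound to a double-bonded chain carbon gives, in this assay, an at least 7.1-fold lower number from compound 2 to compound 4 (0.85 log units; beyond the scatter). This shows that the group at this place can move the read-out beyond the scatter, and that compound 4 reaches a measurable number. The earlier compounds showed no such movement, since each stood at a limit, the commonest being this one: the limit of > 50000 nM in this assay, at which 2 of the 4 values shown sit.

On these data alone, the true size of the step stays open, since one end of it is a limit. Also open, as far as these compounds go, is whether the chlorine or the carbon-only ring carries the change, which a plain phenyl or a pyridin-2-yl at this place would help to settle.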